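Ester side-chain swap on the shared glycoside core

This account rests on a few compounds, and the source may have more. Where it says the series, first, only, none or still open, it means among the compounds named here.

Within the data shown here, compound 1 `C/C=C1/[C@H](O[C@@H]2O[C@H](CO)[C@@H](O)[C@H](O)[C@H]2O)OC=C(C(=O)OC)[C@H]1CC(=O)OCCC1CCCCC1` is the only compound in this set with a numerical result in a functional assay on SK-BR-3 cells (Homo sapiens) for antiproliferative activity, read by MTT assay, with a stated time of 72 h; on this read-out lower numbers stand for stronger inhibition and higher numbers for weaker inhibition; in this assay compound 1 gives 2000 nM. Compound 2 `C/C=C1/[C@H](O[C@@H]2O[C@H](COC(C)=O)[C@@H](OC(C)=O)[C@H](OC(C)=O)[C@H]2OC(C)=O)OC=C(C(=O)O)[C@H]1CC(=O)OCCCCCCCCCCCCCCC` is recorded only at the limit of this assay, > 20000 nM, which is a limit and not a number (the limit of > 20000 nM in this assay, at which 1 of the 2 values shown sits). Among the measured compounds shown here, no two measured compounds differ in a single place, so no measured step within this assay is available. Compound 3 `C/C=C1/[C@H](O[C@@H]2O[C@H](CO)[C@@H](O)[C@H](O)[C@H]2O)OC=C(C(=O)OC)[C@H]1CC(=O)OCc1ccc(OC)c(OC)c1` differs from compound 1 by 3,4-dimethoxyphenyl in place of cyclohexylmethyl on a saturated chain carbon bound to an oxygen next to a carbonyl group. For the measured compounds named here, with no measured step to lean on, the change from compound 1 to compound 3 in this assay is expected to stay within the usual scatter, with no preferred direction. For compound 3 the estimate in this assay is 2500 nM, within a range from 800 nM to 8000 nM, corresponding to an expected step of a 1.3-fold higher number from compound 1 to compound 3 (0.10 log units; within the scatter).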

Compound 3, half-maximal inhibitory concentration: > 15000 nM
Compound 3: only a limit was reported; the forecaster's own chance of this, stated with the estimate: 10%; at least 6.0-fold (0.77 log units) between middle value and limit.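

At this position a single change can now be read in this assay: 3,4-dimethoxyphenyl in place of cyclohexylmethyl on a saturated chain carbon bound to an oxygen next to a carbonyl group gives an at least 7.5-fold higher number from compound 1 to compound 3 (0.87 log units; beyond the scatter). On these data alone, compound 3 is recorded only as a limit of the assay, not as a number: the limit of > 15000 nM in this assay, at which 1 of the 3 values shown sits. The side chain is therefore a place where a single swap on the shared core moves the read-out beyond the scatter, towards weaker inhibition, and the full size of that step stays unknown.

The compounds shown leave open which part of the change carries the step: the ring, the two methoxy groups, or the chain, as 2-cyclohexylethyl gives way to 3,4-dimethoxybenzyl. An unsubstituted 2-phenylethyl group at this place would bear directly on that question.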